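Methylsulfonyl for chloro on the benzamide ring

The compounds below may be only part of what the source reports. "The series", "measured", "known", "first", "only" and "open" are said of these compounds alone.

Compound 1 `O=C(Nc1ccc(Cl)c(-c2nnc3c(Cl)cccn23)c1)c1ccc(C(F)(F)F)cc1Cl` — > 100000 nM
Compound 2 `O=C(Nc1ccc(Cl)c(-c2nnc3c(Cl)cccn23)c1)c1cccc(Cl)c1` — > 100000 nM
Compound 3 `O=C(Nc1ccc(Cl)c(-c2nnc3c(Cl)cccn23)c1)c1cccnc1Cl` — 87500 nM

In a functional assay on HeLa cells (Homo sapiens) for antiproliferative activity, read by MTT assay, with a stated time of 72 h (on this read-out higher numbers stand for weaker inhibition and lower numbers for stronger inhibition), compound 1 gives > 100000 nM, which is a limit of the assay rather than a number. Compound 2 likewise gives > 100000 nM, again a limit. Only compound 3 returns a number, 87500 nM, and the move an at least 1.1-fold lower number from compound 2 to compound 3 (0.05 log units; that floor lies within the scatter) lies within the scatter. Two of the three values shown sit at the limit of > 100000 nM in this assay, at which 2 of the 3 values shown sit, so compound 2 stands at the weak end, with no number to anchor it.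

Compound 4 `CS(=O)(=O)c1cccc(C(=O)Nc2ccc(Cl)c(-c3nnc4c(Cl)cccn34)c2)c1` has not yet been measured. It differs from compound 2 by methylsulfonyl in place of chloro on an aromatic carbon — read one bond further out, 3-chlorophenyl becomes 3-(methylsulfonyl)phenyl. Going by the values given here, the only measured step that touches this ring is the one from compound 2 to compound 3, and it showed no movement beyond the scatter. Nothing here points to a step beyond the scatter for compound 4 either.

Compound 4 is therefore expected near 100000 nM, in the range 30000 nM to 300000 nM. The expected step is a number no higher from compound 2 to compound 4 (the limit leaves the size open), and a limit rather than a number is considered likely for compound 4.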

Compound 4, half-maximal inhibitory concentration: 86400 nM
Beside the measured number, compound 4's estimate is 1.2-fold (0.06 log units) above it; the measured number falls inside the stated range.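

In this assay methylsulfonyl in place of chloro on this aromatic carbon, meta to a large group, gives compound 4 a number rather than a limit, yet an at least 1.1-fold lower number from compound 2 to compound 4 (0.06 log units; that floor lies within the scatter) sets only a floor for the change. Likewise a 1.0-fold lower number from compound 3 to compound 4 (0.01 log units; within the scatter) puts no order between 3-(methylsulfonyl)phenyl and 2-chloropyridin-3-yl on the carbonyl carbon. The full size of the change from chloro to methylsulfonyl cannot be read because compound 2 stands at a limit: the limit of > 100000 nM in this assay, at which 2 of the 4 values shown sit.

The compounds shown leave open whether an amine or a carboxylic acid on this aromatic carbon would give a step beyond the scatter. They also leave open whether methylsulfonyl would read the same on a benzamide ring that also carries trifluoromethyl.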